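A few compounds are considered here, and "the series" means these few. Any claim that something is new, unique, unknown or untested is made for them only; others in the source may bear on it.

Compound 1, `COc1ccc2[nH]c(C(=O)N3CC(=O)N(Cc4ccccc4)[C@@H](COc4ccccc4)C3)cc2c1`: in an ADME assay on Vero cells (Chlorocebus sabaeus) for cytotoxicity, with a stated time of 7 days (a lower number here means that less compound is tolerated, a higher number that more compound is tolerated), compound 1 gives > 10000 nM, which is a limit of the assay and not a number.
Compound 2, `COc1ccc2[nH]c(C(=O)N3CC(=O)N(Cc4ccccc4)[C@@H](Cc4ccccn4)C3)cc2c1`: in this assay compound 2 gives > 30000 nM, again a limit of the assay and not a number.

For the measured compounds named here, compound 2 thus stands at a limit in this assay, and the only other value shown, that of compound 1, is a limit as well. Compound 3, `COc1ccc2[nH]c(C(=O)N3CC(=O)N(Cc4ccccc4)[C@@H](N4CCc5ccccc54)C3)cc2c1`, has not yet been measured in this assay. It differs from compound 2 by 2,3-dihydro-1H-indol-1-yl in place of (pyridin-2-yl)methyl on a saturated ring carbon, a change on a saturated ring carbon of the shared core. Going by the values given here, the single measured step that bears on it, a step that the two limits leave unreadable from compound 1 to compound 2, also concerns a change on that saturated ring carbon, but its size cannot be read, since both of its values sit at limits, the limit of > 10000 nM in this assay, at which 1 of the 2 values shown sits, and (the limit of > 30000 nM in this assay, at which 1 of the 2 values shown sits). No readable step is therefore available, and in this assay no step beyond the scatter can be expected in either direction from compound 2 to compound 3. It is expected that compound 3 will again report a limit rather than a number. Compound 3 is estimated at 30000 nM, with a range from 10000 nM to 100000 nM, which corresponds to an expected step of a number no higher from compound 2 to compound 3 (the limit leaves the size open).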

Compound 3, half-maximal cytotoxic concentration: > 100000 nM
Compound 3 was reported as a limit (the forecaster's own chance of this, stated with the estimate: 80%); at least 3.3-fold (0.52 log units) between middle value and limit.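

In this assay compound 3 gives > 100000 nM, a limit of the assay and not a number. For the compounds shown here, compound 1, compound 2 and compound 3 now all stand at limits, and no step among them can be read. The compounds shown leave open whether the group on that saturated ring carbon changes the tolerated concentration at all.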